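The source may hold more compounds than are shown below. What is called first, only, known or untested is meant among the compounds shown, and "the series" means these compounds.

Among the measured compounds shown here, compound 2 `CN(CCCCCCOc1ccc2oc(-c3ccccc3)cc(=O)c2c1)Cc1ccccc1` stands lowest of the two numbers so far: in an assay on isolated protein (Cavia porcellus) with Sigma non-opioid intracellular receptor 1 (Homo sapiens) as the target, read by radioligand binding (a higher number here means a weaker inhibitor, a lower number a stronger inhibitor), compound 2 gives 75 nM, whereas compound 1 `CN(C)CCCCCCOc1ccc2oc(-c3ccccc3)cc(=O)c2c1` gives 335 nM. For the measured compounds named here, the only step seen, a 4.5-fold lower number from compound 1 to compound 2 (0.65 log units; beyond the scatter), concerns the substituent on the amine nitrogen. Compound 3 `CCN(CC)CCCCCCOc1ccc2oc(-c3ccccc3)cc(=O)c2c1` carries diethylamino in place of benzyl(methyl)amino on a saturated chain carbon, six bonds along the chain from an oxygen on an aromatic ring. Going by the values given here, no measured step covers ethyl in place of methyl or benzyl on that nitrogen; the earlier step shows only that this substituent matters at the modest size recorded. Expected: a 2.0-fold higher number from compound 2 to compound 3 (0.30 log units; within the scatter), partly reversing that gain. Compound 3 is therefore estimated at 150 nM in this assay, between 50 nM and 450 nM.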

Compound 3, half-maximal inhibitory concentration: 100 nM
For compound 3 the middle estimate is 1.5-fold (0.18 log units) above the measured one, within the range that was stated.
By their numbers in this assay, from the lowest: compounds 2 and 3 (each within the scatter of the next); then compound 1.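

In this assay, diethylamino in place of benzyl(methyl)amino gives a 1.3-fold higher number from compound 2 to compound 3 (0.12 log units; within the scatter), so on this chain an aromatic ring on the amine is not required for a value of this size. Diethylamino in place of dimethylamino gives a 3.4-fold lower number from compound 1 to compound 3 (0.53 log units; beyond the scatter), so two ethyl groups on the nitrogen recover the gain without any benzyl group. No evidence bears on the reason for either step. Open, from the compounds shown here alone, is whether a cyclic amine such as piperidine or morpholine, or a shorter or longer chain, would hold this level.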